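Working notes: from compound 2 to compound 3

A few compounds are considered here, and "the series" means these few. Any claim that something is new, unique, unknown or untested is made for them only; others in the source may bear on it.

compound 1 `CCCc1nn(C)c2c(NC3CC3)nc(/C=C/c3cccnc3)nc12` — 261000 nM
compound 2 `CNc1nc(/C=C/c2ccccc2)nc2ccsc12` — > 1000000 nM

In a functional assay on L02 cells (Homo sapiens) for inhibition, read by Griess assay, with stated times of 1 h and 24 h (a higher number here means a weaker inhibitor, a lower number a stronger inhibitor), compound 1 gives 261000 nM. For compound 2 the value > 1000000 nM is a limit of the assay and not a number (the limit of > 1000000 nM in this assay, at which 1 of the 2 values shown sits). Compound 2 therefore stands without a fixed position among the values shown. Compound 3 `Clc1ccccc1CNc1nc(/C=C/c2ccccc2)nc2ccsc12` differs from compound 2 by 2-chlorophenyl in place of hydrogen on a saturated chain carbon bound to a nitrogen on an aromatic ring. Among the compounds with values here, no measured step of this kind exists, so the size of the change in this assay is open; a gain is expected, but a further limit would not be surprising. For compound 3 the estimate is 500000 nM, with a range of 100000 nM to 2000000 nM. The step expected is an at least 2.0-fold lower number from compound 2 to compound 3 (0.30 log units; that floor lies within the scatter).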

Compound 3, half-maximal inhibitory concentration: > 1000000 nM
Compound 3 gave a limit, no number; the forecaster's own chance of this, stated with the estimate: 40%; at least 2.0-fold (0.30 log units) between middle value and limit.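

In this assay compound 2 and compound 3 both stand at a limit and not a number, so no step can be read between them: the limit of > 1000000 nM in this assay, at which 2 of the 3 values shown sit.

On these data alone, whether 2-chlorophenyl in place of hydrogen on a saturated chain carbon bound to a nitrogen on an aromatic ring changes inhibition in this assay at all stays open.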